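Turning the inactive acid into an isobutyl ester

The compounds below may be only part of what the source reports. "The series", "measured", "known", "first", "only" and "open" are said of these compounds alone.

Compound 1 (`O=C1C2=C(CCCC2)C(=O)N1c1ccc(Cl)cc1F`) gives 240 nM 
Compound 2 (`O=C(O)c1cc(N2C(=O)C3=C(CCCC3)C2=O)ccc1Cl`) gives > 100000 nM (a limit of the assay)
Compound 3 (`CC(C)OC(=O)c1cc(N2C(=O)C3=C(CCCC3)C2=O)c(F)cc1Cl`) gives 89.1 nM 

All three values come from a functional assay on the whole organism with Scenedesmus acutus as the target, with a stated time of 20 h; a lower number here means a stronger inhibitor, a higher number a weaker inhibitor. Compound 2 sits at a limit and has no exact number (the limit of > 100000 nM in this assay, at which 1 of the 3 values shown sits). Compound 4 (`CC(C)COC(=O)c1cc(N2C(=O)C3=C(CCCC3)C2=O)ccc1Cl`) is not yet measured and differs from compound 2 by isobutyl in place of hydrogen on an oxygen next to a carbonyl group, which is isobutyl in place of hydrogen on an oxygen next to a carbonyl group, turning carboxy into isobutoxycarbonyl.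

Going by the values given here, no measured step makes this exact change. The nearest is a 2.7-fold lower number from compound 1 to compound 3 (0.43 log units; beyond the scatter), a modest step that puts isopropoxycarbonyl in place of hydrogen on an aromatic carbon. It shows that compound 3, which carries an ester, reaches 89.1 nM in this assay, so a large move toward a lower number is expected here. The expected size is an at least 330-fold lower number from compound 2 to compound 4 (2.52 log units; beyond the scatter) and remains uncertain, since the start is only a limit. The estimate for compound 4 is 300 nM, with an expected range from 60 nM to 2000 nM.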

Compound 4, half-maximal inhibitory concentration: 15500 nM
Beside the measured number, compound 4's estimate is 52-fold (1.71 log units) below it; measured number outside the range, above it.
By their numbers in this assay, from the lowest: compound 3; then compound 1; then compound 4. At a limit, above all of these: compound 2.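

Turning carboxy into isobutoxycarbonyl, with isobutyl in place of hydrogen on an oxygen next to a carbonyl group, gives the first pair here in which only this group changes: in this assay the change brings an at least 6.4-fold lower number from compound 2 to compound 4 (0.80 log units; beyond the scatter). Compound 4 therefore has a measured number on this core, 15500 nM, whereas the free acid gave no exact number. Compound 2 has only a limit, so the true size of this step remains a minimum: the limit of > 100000 nM in this assay, at which 1 of the 4 values shown sits.

The compounds shown leave open how a methyl group or a longer chain on that oxygen, or an amide in place of the ester, would read. Compound 3 and compound 4 differ in more than one place, so they cannot rank isopropoxycarbonyl against isobutoxycarbonyl on a single core.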